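A few compounds are considered here, and "the series" means these few. Any claim that something is new, unique, unknown or untested is made for them only; others in the source may bear on it.

Of the compounds shown here, two of the same series have been measured for binding at the histamine H2 receptor. Compound 1, `Cc1nc(N)sc1CCCN/C(N)=N/C(=O)NC(C)c1ccc(OC(F)(F)F)cc1`, carries a 4-(trifluoromethoxy)phenyl group on the chain carbon next to the urea part of the molecule, and in an assay on membranes from Sf9 cells for displacement of a labelled ligand from histamine H2 receptor (Homo sapiens), read by scintillation counting, with a stated time of 60 min (a lower number here means a stronger inhibitor, a higher number a weaker inhibitor), compound 1 gives 126 nM. Compound 2, `Cc1nc(N)sc1CCCN/C(N)=N/C(=O)NC(C)c1ccco1`, carries a furan-2-yl group at that same position instead, and in this assay compound 2 gives 31.6 nM. Within the data shown here, of the two numbers known so far, compound 2 has the lower one, and its gap to compound 1 is beyond the usual scatter of this kind of measurement, so compound 2 is the stronger binder of the pair.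

The next compound, compound 3, `Cc1nc(N)sc1CCCN/C(N)=N/C(=O)NC(C)c1ccc(Cl)cc1`, differs from compound 2 in one place: 4-chlorophenyl in place of furan-2-yl on a saturated chain carbon bound to an amide-type nitrogen and a saturated chain carbon. Among the measured compounds shown here, because compound 1, the only other measured compound with a substituted phenyl group at this position, gives 126 nM, the change is expected to weaken binding somewhat, though by less than the gap between compound 1 and compound 2. The expected step of a 2.5-fold higher number from compound 2 to compound 3 (0.40 log units; beyond the scatter) is a modest rise in the number. Compound 3 is therefore estimated at 80 nM, with a likely range from 30 nM to 220 nM.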

Compound 3, inhibition constant: 46.8 nM
Beside the measured number, compound 3's estimate is 1.7-fold (0.23 log units) above it, and the stated range covers the measured number.
By their numbers in this assay, from the lowest: compounds 2 and 3 (each within the scatter of the next); then compound 1.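

Swapping furan-2-yl for 4-chlorophenyl on a saturated chain carbon bound to an amide-type nitrogen and a saturated chain carbon gives a 1.5-fold higher number from compound 2 to compound 3 (0.17 log units; within the scatter), so in this assay this position accepts either a five-membered aromatic ring with an oxygen or a six-membered carbon ring bearing chloro without a change that can be told from scatter. Within the phenyl pair, chloro in place of trifluoromethoxy on an aromatic carbon gives a 2.7-fold lower number from compound 1 to compound 3 (0.43 log units; beyond the scatter), which shows that the number here depends on the group carried by the phenyl ring and not merely on the presence of a phenyl ring. No separate measurement is available to explain either result.

The compounds shown leave open whether an unsubstituted phenyl group, or a phenyl group carrying methoxy or fluoro in place of chloro, would give a number close to that of compound 3 or that of compound 1. They also leave open how another five-membered aromatic ring, such as thiophen-2-yl, would compare with the furan-2-yl group of compound 2.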